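Cytotoxicity notes on a dichlorophenyl-substituted methylene-oxindole series

The source may hold more compounds than are shown below. What is called first, only, known or untested is meant among the compounds shown, and "the series" means these compounds.

Measured so far:
compound 1 `O=C1/C(=C\c2c(Cl)cccc2Cl)c2ccccc2N1c1c(Cl)cccc1Cl`: > 100 ug/mL
compound 2 `O=C1/C(=C\c2cc3ccccc3nc2Cl)c2ccccc2N1c1c(Cl)cccc1Cl`: "not determined" (no result reported)

In a functional assay on L132 cells (Homo sapiens) for cytotoxicity, read by MTT assay, with a stated time of 72 h (a higher number here means that more compound is needed for the effect, a lower number that less compound is needed), compound 1 gives > 100 ug/mL, which is a limit of the assay and not a number. Compound 2 has no reported result in this assay. Compound 1 thus stands on the limit of > 100 ug/mL in this assay, at which 1 of the 2 values shown sits, and on nothing more definite.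

Compound 3 `CN(C)c1ccc(/C=C2\C(=O)N(c3c(Cl)cccc3Cl)c3ccccc32)cc1` differs from compound 1 by 4-(dimethylamino)phenyl in place of 2,6-dichlorophenyl on a double-bonded chain carbon bound to a double-bonded ring carbon. For the measured compounds named here, no measured step is available for this assay, so the size of the change from compound 1 to compound 3 is a matter of expectation only, and a step of no more than the scatter is expected, in either direction.

For compound 3 the expected value in this assay is 100 ug/mL, with a range from 40 ug/mL to 250 ug/mL, a step of a number no higher from compound 1 to compound 3 (the limit leaves the size open) that is an estimate.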

Compound 3, concentration for half-maximal effect: > 100 ug/mL
Compound 3 gave a limit, no number; the forecaster's own chance of this, stated with the estimate: 60%; the middle value sits exactly at the limit.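

No step can be read from compound 1 to compound 3, since both results are limits and not numbers: the limit of > 100 ug/mL in this assay, at which 2 of the 3 values shown sit. The compounds shown leave open whether 4-(dimethylamino)phenyl in place of 2,6-dichlorophenyl changes the result at all in this assay.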